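The compounds below may be only part of what the source reports. "The series", "measured", "known", "first", "only" and "open" are said of these compounds alone.

Series notes. The shared core carries a linker of one oxygen between two carbons, ending in a benzene ring that bears the varied group. Compound 1 `[O-][n+]1nc(NCOCc2ccc(C(F)(F)F)cc2)[n+]([O-])c2ccccc21` carries trifluoromethyl, compound 2 `COc1ccc(COCNc2n[n+]([O-])c3ccccc3[n+]2[O-])cc1` methoxy, compound 3 `[O-][n+]1nc(NCOCc2ccccc2)[n+]([O-])c2ccccc21` hydrogen at that position. In a functional assay on PC-3 cells (Homo sapiens) for cytotoxicity, read by MTT assay, with a stated time of 72 h (on this read-out higher numbers stand for weaker inhibition and lower numbers for stronger inhibition), compound 1 gives 7650 nM, compound 2 gives 14500 nM, and compound 3 gives 13400 nM. All three numbers lie within the scatter of one another: the nearest neighbour of compound 3 is compound 2, with a 1.1-fold lower number from compound 2 to compound 3 (0.03 log units; within the scatter), and the furthest is compound 1, with a 1.8-fold higher number from compound 1 to compound 3 (0.24 log units; within the scatter); between the other two, a 1.9-fold higher number from compound 1 to compound 2 (0.28 log units; within the scatter).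

Compound 4 `O=[N+]([O-])c1cccc(COCNc2n[n+]([O-])c3ccccc3[n+]2[O-])c1` is unmeasured. Relative to compound 3 the change is nitro in place of hydrogen on an aromatic carbon. The measured steps that bear on it are those that exchanged the group on the same ring: from compound 1 to compound 3, a 1.8-fold higher number from compound 1 to compound 3 (0.24 log units; within the scatter), and from compound 2 to compound 3, a 1.1-fold lower number from compound 2 to compound 3 (0.03 log units; within the scatter). Neither left the scatter, so no change beyond the scatter is expected for nitro in this assay either; the nitro group sits meta to a large group, a placement not sampled by the three measured compounds, which widens the range. Compound 4 is expected at 13000 nM, between 5500 nM and 30000 nM, which means an expected step of a 1.0-fold lower number from compound 3 to compound 4 (0.01 log units; within the scatter).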

Compound 4, half-maximal inhibitory concentration: 3070 nM
Beside the measured number, compound 4's estimate is 4.2-fold (0.63 log units) above it; measured number below the stated range.
By their numbers in this assay, from the lowest: compound 4; then compounds 1, 3 and 2 (each within the scatter of the next).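

In this assay, nitro in place of hydrogen on an aromatic carbon, meta to a large group, gives a 4.4-fold lower number from compound 3 to compound 4 (0.64 log units; beyond the scatter), a modest step and the only exchange on this ring shown to leave the scatter. The other exchanges on the ring, a 1.8-fold higher number from compound 1 to compound 3 (0.24 log units; within the scatter) and a 1.1-fold lower number from compound 2 to compound 3 (0.03 log units; within the scatter), stay within it, so the flat picture from compounds 1, 2 and 3 does not hold for the ring as a whole: this read-out can respond to a change there. No measurement shown bears on the reason for this step.

The compounds shown leave nitro and its placement joined, so it remains open whether the step in compound 4 follows from the group itself, from its place meta to a large group, or from both; nitro at the ring position occupied by trifluoromethyl in compound 1 and methoxy in compound 2 would separate these. Also open, from the compounds shown here alone, is whether an amine or a carboxylic acid at the place of the nitro group would give a step of similar size, and whether the step would persist with a longer chain in the linker.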